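Nucleoside series: replacing the furanylmethylamino substituent

The compounds below may be only part of what the source reports. "The series", "measured", "known", "first", "only" and "open" are said of these compounds alone.

Measured compounds in an assay on isolated protein for binding affinity to Equilibrative nucleoside transporter 1 (Homo sapiens); on this read-out lower numbers stand for stronger inhibition and higher numbers for weaker inhibition:
compound 1 `OC[C@H]1O[C@@H](n2cnc3c(NCc4ccco4)ncnc32)[C@H](O)[C@@H]1O` gives 36300 nM
compound 2 `OC[C@H]1O[C@@H](n2cnc3c(SC4CCCCC4)ncnc32)[C@H](O)[C@@H]1O` gives 6310 nM
compound 3 `OC[C@H]1O[C@@H](n2cnc3c(CSc4cccc(Br)c4)ncnc32)[C@H](O)[C@@H]1O` gives 363 nM

Compound 1 has the highest number of the three; compound 2 stands nearest to it, with a 5.8-fold lower number from compound 1 to compound 2 (0.76 log units; beyond the scatter), and compound 3 furthest, with a 100-fold lower number from compound 1 to compound 3 (2.00 log units; beyond the scatter). The gap between the two sulfur-linked compounds is a 17-fold lower number from compound 2 to compound 3 (1.24 log units; beyond the scatter), so the aryl-bearing compound 3 is the strongest of the set.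

Compound 4 `O=[N+]([O-])c1cc(CNc2ncnc3c2ncn3[C@@H]2O[C@H](CO)[C@@H](O)[C@H]2O)ccc1Cl` is not yet measured. It differs from compound 1 in one place: 4-chloro-3-nitrophenyl in place of furan-2-yl on a saturated chain carbon bound to a nitrogen on an aromatic ring. The shared core and the aminomethyl linkage are kept; only the ring on the chain carbon changes.

For the measured compounds named here, no measured step alters this ring alone. The two steps from compound 1 both replace the whole substituent, and both lower the number, the larger one where an aryl ring enters in compound 3. For compound 4 a lower number is therefore expected, of a size around a 9.1-fold lower number from compound 1 to compound 4 (0.96 log units; beyond the scatter), though less surely than for the measured steps. The estimate for compound 4 in this assay is 4000 nM, within 800 nM to 20000 nM.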

Compound 4, half-maximal inhibitory concentration: 708 nM
Compound 4: the middle estimate sits 5.6-fold (0.75 log units) above what was measured; the measured number lies below the stated range.
By their numbers in this assay, from the lowest: compounds 3 and 4 (each within the scatter of the next); then compound 2; then compound 1.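

In this assay, for the compounds shown here, the ring on the saturated chain carbon bound to a nitrogen on an aromatic ring is changed alone for the first time, and 4-chloro-3-nitrophenyl in place of furan-2-yl gives a 51-fold lower number from compound 1 to compound 4 (1.71 log units; beyond the scatter). The earlier steps shown here from compound 1 replaced the whole substituent, whereas this one keeps the aminomethyl linkage, so a large step does not require losing that nitrogen link. No measurement available here explains the effect of this ring change.

The compounds shown leave the contributions of the chlorine and the nitro group unseparated, and a plain phenyl, 4-chlorophenyl or 3-nitrophenyl on the same chain carbon would address this. Also open, from the compounds shown here alone, is how a longer chain in place of the aminomethyl linkage would read with the 4-chloro-3-nitrophenyl ring retained.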